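The source may report more compounds than this note shows. Statements on the series, on what has been measured and on what is new or still open speak of the compounds shown alone.

Compound 3 `CC(C)(C)c1ccc(Nc2cccc3c2C(=O)N(C2CCC(=O)NC2=O)C3=O)cc1` stands highest of the three measured compounds in an assay on FRT-Jurkat cells for inhibition of nuclear factor NF-kappa-B complex (Homo sapiens), read by flow cytometry, with a stated time of 24 h, tested at 10 uM (a higher number here means more inhibition at the concentration tested (going by the name of the read-out), a lower number less inhibition), giving 36%. Compound 1 `COc1ccc(Nc2cccc3c2C(=O)N(C2CCC(=O)NC2=O)C3=O)cc1` gives 13% and compound 2 `C=C(OCC)c1ccc(Nc2cccc3c2C(=O)N(C2CCC(=O)NC2=O)C3=O)cc1` gives 10%. The steps of a number 23 percentage points higher from compound 1 to compound 3 (beyond the scatter) and a number 26 percentage points higher from compound 2 to compound 3 (beyond the scatter) are both beyond the scatter, whereas a number 3 percentage points lower from compound 1 to compound 2 (within the scatter) is not. Compound 4 `CCCc1ccc(Nc2cccc3c2C(=O)N(C2CCC(=O)NC2=O)C3=O)cc1` differs from compound 3 in one place: propyl in place of tert-butyl on an aromatic carbon. Within the data shown here, the two steps that reach compound 3 each bring tert-butyl in for a group containing oxygen, so they bear only loosely on swapping tert-butyl for propyl, and no measured step shows propyl itself. A small drop toward the two lower values, or no change beyond the scatter, is expected, as a number 10 percentage points lower from compound 3 to compound 4 (within the scatter). For compound 4 in this assay the estimate is 26%, with a range from 10% to 42%.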

Compound 4, a percentage reported as inhibition, at one concentration (the size of the read-out at that concentration, not a potency): 23%
Compound 4: middle estimate off by 3 percentage points, on the high side; the measured number falls inside the stated range.
By their numbers in this assay, from the lowest: compounds 2, 1 and 4 (each within the scatter of the next, the first and the last beyond it); then compound 3.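

In this assay, a group made only of carbon at this position does not by itself keep the highest number, as a number 13 percentage points lower from compound 3 to compound 4 (beyond the scatter) shows when tert-butyl gives way to propyl. Propyl still stands clear of 1-ethoxyethenyl, with a number 13 percentage points higher from compound 2 to compound 4 (beyond the scatter), while a number 10 percentage points higher from compound 1 to compound 4 (within the scatter) leaves compound 4 and compound 1 inseparable. No measured evidence explains these differences. Isopropyl, a branched group smaller than tert-butyl, and a longer chain such as butyl would be needed to tell whether branching or chain length matters here.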